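The source may report more compounds than this note shows. Statements on the series, on what has been measured and on what is new or still open speak of the compounds shown alone.

In an ADME assay for pharmacokinetics, read by HPLC (on this read-out lower numbers stand for a shorter-lived compound and higher numbers for a longer-lived compound), compound 1 `CC(=O)O[C@@H]1/C=C(\C)CC[C@]2([C@@](C)(O)C(=O)SCc3oc(=O)oc3C)CC(=O)N([C@H](C)c3nc(cs3)/C=C/C=C/C1=O)[S+]2[O-]` gives 24 h while compound 2 `COC1(O[C@@H]2/C=C(\C)CC[C@]3([C@@](C)(O)C(=O)SCc4oc(=O)oc4C)CC(=O)N([C@H](C)c4nc(cs4)/C=C/C=C/C2=O)[S+]3[O-])CCOCC1` gives 18 h and compound 3 `C/C1=C\[C@@H](O)C(=O)/C=C/C=C/c2csc(n2)[C@@H](C)N2C(=O)C[C@@]([C@@](C)(O)C(=O)SCc3oc(=O)oc3C)(CC1)[S+]2[O-]` gives 16 h so compound 3 lies within the usual scatter of both others. Compound 4 `C/C1=C\[C@@H](O[C@H]2CCCCO2)C(=O)/C=C/C=C/c2csc(n2)[C@@H](C)N2C(=O)C[C@@]([C@@](C)(O)C(=O)SCc3oc(=O)oc3C)(CC1)[S+]2[O-]` differs from compound 3 in one place: the change oxan-2-yl in place of hydrogen on an oxygen on a saturated carbon puts oxan-2-yl in place of hydrogen on an oxygen on a saturated carbon. Going by the values given here, two measured steps concern a group on an oxygen on a saturated carbon. There is a 1.1-fold lower number from compound 2 to compound 3 (0.05 log units; within the scatter) when 4-methoxyoxan-4-yl gives way to hydrogen and a 1.5-fold lower number from compound 1 to compound 3 (0.18 log units; within the scatter) when acetyl does, and both stay within the scatter. No step beyond the scatter is therefore expected in this assay and the expected size is a 1.1-fold higher number from compound 3 to compound 4 (0.05 log units; within the scatter) for this change. Compound 4 is estimated at 18 h with an expected range from 10 h to 30 h in this measurement.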

Compound 4, half-life: 30 h
For compound 4 the middle estimate is 1.7-fold (0.22 log units) below the measured one, and the stated range covers the measured number.
By their numbers in this assay, from the lowest: compounds 3, 2, 1 and 4 (each within the scatter of the next).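

Oxan-2-yl, a ring with one defined stereocentre, now joins acetyl and 4-methoxyoxan-4-yl as a group on this oxygen, and in this assay it also stays close to the free hydroxy, with a 1.9-fold higher number from compound 3 to compound 4 (0.27 log units; within the scatter). It stays equally close to the other two groups, with a 1.7-fold higher number from compound 2 to compound 4 (0.22 log units; within the scatter) and a 1.3-fold higher number from compound 1 to compound 4 (0.10 log units; within the scatter). Every pair of compounds at this position therefore lies within the scatter, now across three different groups and hydrogen. Nothing available explains these numbers. On these data alone, whether a group carrying an amine or a carboxylic acid on this oxygen would give a step beyond the scatter stays open.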